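The source may report more compounds than this note shows. Statements on the series, on what has been measured and on what is new or still open speak of the compounds shown alone.

Among the compounds with values here, in a functional assay on HCT-116 cells (Homo sapiens) for antiproliferative activity, read by MTT assay, with a stated time of 48 h (on this read-out higher numbers stand for weaker inhibition and lower numbers for stronger inhibition), compound 2 (`CCCCCCCCC(CCO)n1cnc2c(Cl)ncnc21`) gives 1650 nM, the lower of the two numbers measured so far, and compound 1 (`CCCCCCCCC(CCO)n1cnc2c(Cl)nc(F)nc21`) gives 24200 nM. Compound 3 (`CCCCCCCCC(CCO)n1cnc2c(Cl)nc(Cl)nc21`) carries chloro in place of hydrogen on an aromatic carbon, between two ring nitrogen atoms: chloro in place of hydrogen on an aromatic carbon. Within the data shown here, the only measured step on that carbon is a 15-fold lower number from compound 1 to compound 2 (1.17 log units; beyond the scatter), a large one, with hydrogen in place of fluoro. Chloro is untested there, so that step, reversed, is only a guide to a sizeable rise in this assay. The expected step is a 4.2-fold higher number from compound 2 to compound 3 (0.63 log units; beyond the scatter). Compound 3 is estimated at 7000 nM, with an expected range of 2000 nM to 25000 nM.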

Compound 3, half-maximal inhibitory concentration: 22200 nM
The estimate for compound 3 lay 3.2-fold (0.50 log units) below the measured number; measured number inside the range.
By their numbers in this assay, from the lowest: compound 2; then compounds 3 and 1 (each within the scatter of the next).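

In this assay, chloro in place of hydrogen on this aromatic carbon gives a 13-fold higher number from compound 2 to compound 3 (1.13 log units; beyond the scatter), so the higher number seen with fluoro at this carbon is not confined to fluoro. Chloro in place of fluoro gives a 1.1-fold lower number from compound 1 to compound 3 (0.04 log units; within the scatter), so the two halogens cannot be told apart here, and compound 2, with hydrogen, keeps the lowest number. No measurement shown bears on why either halogen raises the number. As far as these compounds go, whether an amine or a methoxy group on this carbon would also raise the number remains open. So does whether any group there matches hydrogen.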